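One phenyl group exchanged on the shared core

A few compounds are considered here, and "the series" means these few. Any claim that something is new, unique, unknown or untested is made for them only; others in the source may bear on it.

Compound 1 `CC(C)=CCC/C(C)=C/Cc1c(O)cc2c(c1O)C(=O)C[C@@H](c1cc(O)cc(O)c1)O2` gives < 10000 nM (a limit)
Compound 2 `COc1cc(O)c([C@@H]2CC(=O)c3c(O)cc(O)cc3O2)cc1C/C=C(\C)CCC=C(C)C` gives > 10000 nM (a limit)

In a functional assay on MCF7 cells (Homo sapiens) for cytotoxicity, with a stated time of 72 h (a higher number here means that more compound is needed for the effect, a lower number that less compound is needed), compound 1 stands only at the limit < 10000 nM and has no exact number. Compound 3 `COc1cc([C@@H]2CC(=O)c3c(cc(O)c(C/C=C(\C)CCC=C(C)C)c3O)O2)cc(O)c1O` has not yet been measured. It differs from compound 1 by 3,4-dihydroxy-5-methoxyphenyl in place of 3,5-dihydroxyphenyl on a saturated ring carbon, with 3,4-dihydroxy-5-methoxyphenyl in place of 3,5-dihydroxyphenyl on a saturated ring carbon. Among the measured compounds shown here, no measured step covers this exchange, so no change beyond the scatter is expected in this assay, and the estimated step that the limit leaves unreadable from compound 1 to compound 3 has no firm direction. In this assay compound 3 is estimated at 9000 nM, with an expected range of 3000 nM to 30000 nM for its value.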

Compound 3, half-maximal effective concentration: < 10000 nM
Compound 3 gave a limit, no number; the forecaster's own chance of this, stated with the estimate: 50%; the middle value is on the limit's open side.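

In this assay, compound 1 and compound 3 both stand only at limits, and the step between them cannot be read. The compounds shown leave open how far 3,4-dihydroxy-5-methoxyphenyl in place of 3,5-dihydroxyphenyl shifts the value, or in which direction.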